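The compounds below may be only part of what the source reports. "The series", "measured", "known", "first", "only" and "open" are said of these compounds alone.

Measured compounds in a functional assay on A-431 cells (Homo sapiens) for cytotoxicity, read by MTT assay, with a stated time of 48 h; on this read-out higher numbers stand for weaker inhibition and lower numbers for stronger inhibition:
compound 1 `CCCCCCCCCCCCNC(=O)[C@@H](NS(=O)(=O)c1ccc(C)cc1)[C@@H](C)O` gives 25200 nM
compound 2 `CCCCCCCCCCCCNC(=O)[C@@H](NS(=O)(=O)c1cccs1)[C@@H](C)O` gives 22000 nM
compound 3 `CCCCCCCCCCCCCCCCCCNC(=O)[C@@H](NS(=O)(=O)c1ccc(C)cc1)[C@@H](C)O` gives 34000 nM

Compound 4 `CCCCCCCCCCCCCCCCCCNC(=O)[C@@H](NS(=O)(=O)c1cccs1)[C@@H](C)O` has not yet been measured in this assay. The core of compound 3 differs from that of compound 1 by hexyl in place of hydrogen on a saturated chain carbon, ten or more bonds along the chain from an amide-type nitrogen, and that step reads a 1.3-fold higher number from compound 1 to compound 3 (0.13 log units; within the scatter). The change from compound 3 to compound 4 is thiophen-2-yl in place of 4-methylphenyl on a sulfonyl sulfur. The same change is already seen once, as thiophen-2-yl in place of 4-methylphenyl on a sulfonyl sulfur, where the step was a 1.1-fold lower number from compound 1 to compound 2 (0.06 log units; within the scatter); the surroundings of the place are identical in both pairs, so the change is taken as the same. The step expected from compound 3 to compound 4 is a 1.1-fold lower number from compound 3 to compound 4 (0.05 log units; within the scatter) because a 1.1-fold lower number from compound 1 to compound 2 (0.06 log units; within the scatter) lay within the scatter. Compound 4 is therefore estimated at 30000 nM, with a range from 15000 nM to 60000 nM.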

Compound 4, half-maximal inhibitory concentration: > 200000 nM
Compound 4: a limit, no number (the forecaster's own chance of this, stated with the estimate: 10%); at least 6.6-fold (0.82 log units) between middle value and limit.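

In this assay, thiophen-2-yl in place of 4-methylphenyl on a sulfonyl sulfur does not carry over from the core of compound 1 to the core of compound 3, the new step being an at least 5.8-fold higher number from compound 3 to compound 4 (0.76 log units; beyond the scatter): the same change on two cores in this assay, a 1.1-fold lower number (0.06 log units; within the scatter) from compound 1 to compound 2 and an at least 5.8-fold higher number (0.76 log units; beyond the scatter) from compound 3 to compound 4, at least 6.7-fold (0.82 log units) apart, beyond the scatter of two such steps. Read the other way, the added hexyl also depends on the sulfonyl group, the new step being an at least 9.0-fold higher number from compound 2 to compound 4 (0.95 log units; beyond the scatter): the same change on two cores in this assay, a 1.3-fold higher number (0.13 log units; within the scatter) from compound 1 to compound 3 and an at least 9.0-fold higher number (0.95 log units; beyond the scatter) from compound 2 to compound 4, at least 6.7-fold (0.82 log units) apart, beyond the scatter of two such steps. Compound 4 gives > 200000 nM, which is a limit and not a number, so the true size of both steps and the reason for the break remain unshown: the limit of > 200000 nM in this assay, at which 1 of the 4 values shown sits.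

Open, from the compounds shown here alone, is whether furan-2-yl on the sulfonyl sulfur would follow thiophen-2-yl on each core. Also open, going by these compounds, is how a longer chain would read with either sulfonyl group.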